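Swapping the Pyrazole Group of Compound 2

The compounds below may be only part of what the source reports. "The series", "measured", "known", "first", "only" and "open" are said of these compounds alone.

Three compounds were measured in a functional assay on MV4-11 cells (Homo sapiens) for antiproliferative activity, with a stated time of 6 days, tested at 6.25 uM; a higher number here means a stronger effect of the compound at the concentration tested, a lower number a weaker effect:

Compound 1 `CNC(=O)N1CCCc2ccc(NC(=O)c3cccc(-c4cnn(C)c4)c3)cc21`: 93.5%
Compound 2 `CNC(=O)N1CCCc2ccc(NC(=O)c3ccc(-c4ccn(S(C)(=O)=O)n4)cc3)cc21`: 57.2%
Compound 3 `CNC(=O)N1CCCc2ccc(NC(=O)c3cccc(-c4cnn(C(C)=O)c4)c3)cc21`: 82%

Compound 2 stands lowest of the three; compound 3 is nearest to it and compound 1 furthest, both beyond the scatter. Compound 4 `CNC(=O)N1CCCc2ccc(NC(=O)c3ccc(-c4cnn(C(C)=O)c4)cc3)cc21` has not yet been measured. It differs from compound 2 in one place: 1-acetyl-1H-pyrazol-4-yl in place of 1-(methylsulfonyl)-1H-pyrazol-3-yl on an aromatic carbon. Among the measured compounds shown here, no measured step covers this change. For the measured compounds named here, the only step in the set, a number 11.5 percentage points lower from compound 1 to compound 3 (beyond the scatter), concerns acetyl in place of methyl and was modest. Going by the values given here, compound 3 also carries 1-acetyl-1H-pyrazol-4-yl and gives 82%, the nearest guide, though no step links it to compound 4. Compound 4 is therefore expected to rise from compound 2 by a number 17.8 percentage points higher from compound 2 to compound 4 (beyond the scatter). The estimate for compound 4 is 75%, within 50% to 92%.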

Compound 4, a percentage reported as inhibition, at one concentration (the size of the read-out at that concentration, not a potency): 83.8%
Beside the measured number, compound 4's estimate is 8.8 percentage points below it; the range from low to high includes it.
By their numbers in this assay, from the lowest: compound 2; then compounds 3, 4 and 1 (each within the scatter of the next, the first and the last beyond it).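

In this assay, 1-acetyl-1H-pyrazol-4-yl in place of 1-(methylsulfonyl)-1H-pyrazol-3-yl gives a number 26.6 percentage points higher from compound 2 to compound 4 (beyond the scatter) on an aromatic carbon para to a large group. Among the compounds shown here, this is the only step at this position, and it shows that the read-out there depends on which substituted pyrazole is attached. No measured evidence explains the rise.

On these data alone, the step changes both the group on the pyrazole nitrogen and the point of attachment, so the share of each stays open. As far as these compounds go, how an amine or a carboxylic acid would compare in place of the pyrazole also stays open.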